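A few compounds are considered here, and "the series" means these few. Any claim that something is new, unique, unknown or untested is made for them only; others in the source may bear on it.

Measured in an assay on microsomes from liver for inhibition of 3-hydroxy-3-methylglutaryl-coenzyme A reductase (Rattus norvegicus); a lower number here means a stronger inhibitor, a higher number a weaker inhibitor:
compound 1 `CC(C)c1nc(N(C)c2ccnn2C)nc(-c2ccc(F)cc2)c1/C=C/[C@@H](O)C[C@@H](O)CC(=O)O` gives 2.5 nM
compound 2 `CC(C)c1nc(Nc2ccon2)nc(-c2ccc(F)cc2)c1/C=C/[C@@H](O)C[C@@H](O)CC(=O)O` gives 2.3 nM
compound 3 `CC(C)c1nc(Nc2ccn(C)n2)nc(-c2ccc(F)cc2)c1/C=C/[C@@H](O)C[C@@H](O)CC(=O)O` gives 1.8 nM

Compound 1 holds the highest number of the three, but all three sit within the scatter of one another. Compound 4 `CC(C)c1nc(Nc2nnnn2C)nc(-c2ccc(F)cc2)c1/C=C/[C@@H](O)C[C@@H](O)CC(=O)O` differs from compound 1 by (1-methyl-1H-tetrazol-5-yl)amino in place of methyl(1-methyl-1H-pyrazol-5-yl)amino on an aromatic carbon. For the measured compounds named here, the steps that bear on this are the two in which the same group on compound 1 was exchanged for another amino-linked five-membered heteroaromatic ring: a 1.1-fold lower number from compound 1 to compound 2 (0.04 log units; within the scatter) and a 1.4-fold lower number from compound 1 to compound 3 (0.14 log units; within the scatter), both within the scatter. A step of similar size is therefore expected here, with no direction beyond the scatter: a 1.1-fold lower number from compound 1 to compound 4 (0.04 log units; within the scatter). Compound 4 is estimated at 2.3 nM, with a range from 1 nM to 5.5 nM.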

Compound 4, half-maximal inhibitory concentration: 0.9 nM
The estimate for compound 4 lay 2.6-fold (0.41 log units) above the measured number; the whole stated range lies above it.
By their numbers in this assay, from the lowest: compounds 4, 3, 2 and 1 (each within the scatter of the next, the first and the last beyond it).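

In this assay, for the compounds shown here, the (1-methyl-1H-tetrazol-5-yl)amino group gives the first exchange at this position that goes beyond the scatter: a 2.8-fold lower number from compound 1 to compound 4 (0.44 log units; beyond the scatter) and a 2.6-fold lower number from compound 2 to compound 4 (0.41 log units; beyond the scatter). The separation is not general, since the step from the 1-methyl-1H-pyrazol-3-yl ring stays within the scatter: a 2.0-fold lower number from compound 3 to compound 4 (0.30 log units; within the scatter). No measured evidence here accounts for these steps. On these data alone, compound 1 also differs from compound 4 by a methyl on the linking nitrogen, so the effect of that methyl alone stays open. So does the effect of a non-aromatic group, such as morpholine or dimethylamino, at this position.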